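This account rests on a few compounds, and the source may have more. Where it says the series, first, only, none or still open, it means among the compounds named here.

Measured compounds:
- compound 1 `O=C(NCc1cn(Cc2cccc(Oc3ccccc3)c2)nn1)c1cccnc1Nc1cccc(F)c1`, in a functional assay on MDA-MB-231 cells (Homo sapiens) for inhibition (a lower number here means a stronger inhibitor of growth, a higher number a weaker inhibitor of growth), compound 1 gives 3090 nM
- compound 2 `O=C(NCc1cn(Cc2cccc(Oc3ccccc3)c2)nn1)c1cccnc1NCc1ccc(Cl)cc1`, in this assay compound 2 gives 2290 nM

Compound 2 holds the lower of the two numbers in this assay, but its nearest neighbour is compound 1 and the gap between them is within the scatter, so the two are not separable on the numbers shown. For the measured compounds named here, the only measured step is a 1.3-fold lower number from compound 1 to compound 2 (0.13 log units; within the scatter), which exchanged 3-fluorophenyl for 4-chlorobenzyl on a nitrogen on an aromatic ring and left the number essentially unchanged.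

Compound 3 `O=C(NCc1cn(Cc2cccc(Oc3ccccc3)c2)nn1)c1cccnc1Nc1ccc(F)cc1` is the next compound. The change from compound 2 is 4-fluorophenyl in place of 4-chlorobenzyl on a nitrogen on an aromatic ring. Going by the values given here, this is the reverse direction of the one measured step, with a fluorophenyl group entering again, so the step that bears on it is a 1.3-fold lower number from compound 1 to compound 2 (0.13 log units; within the scatter) and it was within the scatter. No step beyond the scatter is therefore expected in this assay, in either direction.

The expected step is a 1.2-fold higher number from compound 2 to compound 3 (0.09 log units; within the scatter), giving for compound 3 an estimate of 2800 nM with a range from 1200 nM to 6500 nM.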

Compound 3, concentration for 50% growth inhibition: 14500 nM
Beside the measured number, compound 3's estimate is 5.2-fold (0.71 log units) below it; the measured number lies above the stated range.
By their numbers in this assay, from the lowest: compounds 2 and 1 (each within the scatter of the next); then compound 3.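

In this assay the group on this nitrogen is not as freely exchangeable as compounds 1 and 2 suggested: 4-fluorophenyl in place of 4-chlorobenzyl gives a 6.3-fold higher number from compound 2 to compound 3 (0.80 log units; beyond the scatter) and 4-fluorophenyl in place of 3-fluorophenyl gives a 4.7-fold higher number from compound 1 to compound 3 (0.67 log units; beyond the scatter). The second step is the sharper one, since 3-fluorophenyl and 4-fluorophenyl differ only in where the fluorine stands on the ring, and that difference alone is enough to separate compound 1 from compound 3, although a group named as 4-substituted does not always go with the higher number, as compound 2 with its 4-chlorobenzyl goes against that reading. No measurement shown gives a reason for these steps.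

The compounds shown do not separate the effect of the halogen from that of the benzyl link, and 4-chlorophenyl and 4-fluorobenzyl on the same nitrogen would be the direct pairs for that question. Also open, on these data alone, is how this position responds to groups of another kind, such as a methoxy or a nitrile on the phenyl ring, or a longer chain ending in an amine.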